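Solubility notes on the indole amide series, compound 3

This account rests on a few compounds, and the source may have more. Where it says the series, first, only, none or still open, it means among the compounds named here.

Compound 1 `COc1ccc2[nH]c(C(=O)N3CC(=O)N(Cc4ccccc4)[C@@H](CN4CCCCC4)C3)cc2c1` gives in a physicochemical assay for solubility, read by spectrophotometry, in phosphate buffer, with a stated time of 2 h, at pH 7.4 (a higher number here means a more soluble compound, a lower number a less soluble compound), only a limit, > 25000 nM. Among the measured compounds shown here, compound 2 `COc1ccc2[nH]c(C(=O)N3CC(=O)N(Cc4ccccc4)[C@@H](N4[C@H](C)CCC[C@@H]4C)C3)cc2c1` gives 100000 nM in this assay, the only full number in the set. For the measured compounds named here, the single measured step, a step that the limit leaves unreadable from compound 1 to compound 2, stays unreadable because of the limit of > 25000 nM in this assay, at which 1 of the 2 values shown sits. Compound 3 `COc1ccc2[nH]c(C(=O)N3CC(=O)N(Cc4ccccc4)[C@@H](CN4CCn5cccc5C4)C3)cc2c1` differs from compound 2 by a group of 10 heavy atoms (8 carbon, 2 nitrogen; one five-membered aromatic ring with 1 hetero atom, one six-membered non-aromatic ring with 2 hetero atoms) in place of a group of 8 heavy atoms (7 carbon, 1 nitrogen; one six-membered non-aromatic ring with 1 hetero atom), on a saturated ring carbon. With no readable step to lean on, no step beyond the scatter is expected, and compound 3 is estimated at 70000 nM, range 20000 nM to 150000 nM in this assay, which means an expected step of a 1.4-fold lower number from compound 2 to compound 3 (0.15 log units; within the scatter).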

Compound 3, solubility: 29700 nM
For compound 3 the middle estimate is 2.4-fold (0.37 log units) above the measured one, and the stated range covers the measured number.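

Among the compounds shown here, at this saturated ring carbon, the entering group with its five-membered aromatic ring and six-membered non-aromatic ring, in place of 2,6-dimethylpiperidin-1-yl, goes with a 3.4-fold lower number from compound 2 to compound 3 (0.53 log units; beyond the scatter) and gives the series its only readable step size at this position. The read-out at this position therefore does shift with the group carried there, which compound 1 and compound 2 alone could not show. The steps from compound 1 cannot be read: the limit of > 25000 nM in this assay, at which 1 of the 3 values shown sits.

Still open, as far as these compounds go, is how a morpholin-4-yl group or a primary amine on this carbon would read in this assay and whether such groups would stay within the scatter of compound 2. With a single readable step, no trend across groups at this position can be stated.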